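The compounds below may be only part of what the source reports. "The series", "measured", "known", "first", "only" and "open" are said of these compounds alone.

Compound 1 `CCOc1ccc2c(c1)OC(c1cccc([N+](=O)[O-])c1)C(c1ccccc1)C2=O` and compound 2 `CCOc1ccc2c(c1)OC(c1ccc([N+](=O)[O-])cc1)C(c1ccccc1)C2=O` share the same core and differ only in the nitrophenyl group on the saturated ring carbon. In an ADME assay on PBMC cells (Homo sapiens) for cytotoxicity, read by MTT assay, with a stated time of 5 days (on this read-out higher numbers stand for lower toxicity in this test and lower numbers for higher toxicity in this test), compound 1 reaches only the limit of > 2500000 nM. In this assay compound 2 gives 1360000 nM. The step of an at least 1.8-fold lower number from compound 1 to compound 2 (0.26 log units; that floor lies within the scatter) rests on that limit (the limit of > 2500000 nM in this assay, at which 1 of the 2 values shown sits), so it shows no real difference between the two. Within the data shown here, compound 2 therefore holds the only number in the set; the other value shown is a limit. Compound 3 `CCOc1ccc2c(c1)OC(c1ccc(Cl)cc1)C(c1ccccc1)C2=O` differs from compound 2 by chloro in place of nitro on an aromatic carbon. Among the measured compounds shown here, no measured step exchanges nitro for another group; the one measured step, an at least 1.8-fold lower number from compound 1 to compound 2 (0.26 log units; that floor lies within the scatter), concerns the nitrophenyl variant only and lies within the scatter. The step of a 1.1-fold higher number from compound 2 to compound 3 (0.04 log units; within the scatter) is therefore expected to stay within the scatter. Compound 3 is estimated at 1500000 nM, with a range from 500000 nM to 5000000 nM, and a fair chance that only a limit is reported.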

Compound 3, half-maximal cytotoxic concentration: > 2500000 nM
Compound 3: only a limit was reported; the forecaster's own chance of this, stated with the estimate: 40%; at least 1.6-fold (0.22 log units) between middle value and limit.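

Chloro in place of nitro on the aromatic carbon is the first exchange of the nitro group itself in these notes, and it gives an at least 1.8-fold higher number from compound 2 to compound 3 (0.26 log units; that floor lies within the scatter) in this assay, so it shows no real difference between the two compounds. Among these compounds, on the aromatic carbon para to a large group, nitro and chloro therefore cannot be told apart in this test, and compound 2 remains the only compound with a number rather than a limit. The step from compound 1 to compound 3 cannot be read: the limit of > 2500000 nM in this assay, at which 2 of the 3 values shown sit.

The compounds shown leave open whether any replacement at this place gives a step beyond the scatter. An amine or a carboxylic acid on this aromatic carbon would test that directly, ideally with a result that is a number rather than a limit.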